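The source may report more compounds than this note shows. Statements on the series, on what has been measured and on what is new or still open speak of the compounds shown alone.

Going by the values given here, in a physicochemical assay for lipophilicity, read by HPLC, at pH 7.5 (on this read-out lower numbers stand for lower lipophilicity and higher numbers for higher lipophilicity), compound 1 `CC[C@@H](Nc1c(C#N)c(-c2ccc(-c3ncccc3C)cc2)nc2cnccc12)C(N)=O` gives 2, and compound 2 `CC[C@@H](Nc1c(C#N)c(-c2ccc(-c3cccc(Cl)c3)cc2)nc2cnccc12)C(N)=O` gives 3.1, the higher of the two numbers so far. Compound 3 `CC[C@@H](Nc1c(C#N)c(-c2ccc(-c3ccccc3CO)cc2)nc2cnccc12)C(N)=O` differs from compound 2 at one place: 2-(hydroxymethyl)phenyl in place of 3-chlorophenyl on an aromatic carbon. Among the compounds with values here, the one measured step that bears on this is large, a number 1.10 log units higher from compound 1 to compound 2 (beyond the scatter), and it came with 3-chlorophenyl in place of 3-methylpyridin-2-yl. Here the 3-chlorophenyl leaves again, but a different group enters, so a smaller move downward is expected. The expected step is a number 0.60 log units lower from compound 2 to compound 3 (beyond the scatter). For compound 3 the estimated value is 2.5, with an expected range from 2 to 3.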

Compound 3, distribution coefficient: 2.1
Compound 3: middle estimate off by 0.40 log units, on the high side; the range from low to high includes it.
By their numbers in this assay, from the lowest: compounds 1 and 3 (each within the scatter of the next); then compound 2.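

At this position, 2-(hydroxymethyl)phenyl in place of 3-chlorophenyl gives a number 1.00 log units lower from compound 2 to compound 3 (beyond the scatter) in this assay, so the drop no longer depends on a pyridine-type ring entering: this entering group has a ring of carbon only. Against 3-methylpyridin-2-yl, the same group gives a number 0.10 log units higher from compound 1 to compound 3 (within the scatter), so these two groups cannot be told apart on this read-out. Nothing at hand explains either step. Going by these compounds, whether an amine or a carboxylic acid on this ring would shift the number further remains open. So does the effect of moving the hydroxymethyl group, as in 3-(hydroxymethyl)phenyl.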